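The source may report more compounds than this note shows. Statements on the series, on what has been measured and on what is new or still open speak of the compounds shown alone.

Notes on the series. The shared core appears in compound 1 `O=c1c(-c2nnc(COc3ccc4ccccc4c3)o2)cn(C2CC2)c2cc(N3CCNCC3)c(F)cc12` and compound 2 `O=c1c(-c2nnc(-c3ccccc3)o2)cn(C2CC2)c2cc(N3CCNCC3)c(F)cc12`, both measured, and in compound 3 `O=c1c(-c2nnc(-c3ccc(Nc4ccccc4)cc3)o2)cn(C2CC2)c2cc(N3CCNCC3)c(F)cc12`, not yet measured. In a functional assay on A549 cells (Homo sapiens) for cytotoxicity, read by MTT assay (on this read-out higher numbers stand for weaker inhibition and lower numbers for stronger inhibition), compound 1 gives 16 ug/mL. In this assay, among the compounds with values here, compound 2 gives 46 ug/mL, the highest of the two numbers so far; its nearest neighbour is compound 1, and the single measured step is a 2.9-fold higher number from compound 1 to compound 2 (0.46 log units; beyond the scatter), modest but beyond the scatter. Compound 3 differs from compound 2 by anilino in place of hydrogen on an aromatic carbon, an anilino in place of hydrogen on an aromatic carbon, para to a large group. Only a 2.9-fold higher number from compound 1 to compound 2 (0.46 log units; beyond the scatter) bears on this change: there the compound carrying the larger group on the ring attached to the core gave the lower number. Compound 3 again carries a larger group than compound 2, so by analogy with a 2.9-fold higher number from compound 1 to compound 2 (0.46 log units; beyond the scatter) a modest lowering in this assay is expected, though one step is thin ground and a value within the scatter of compound 2 would not surprise. For compound 3 the expected step is a 1.8-fold lower number from compound 2 to compound 3 (0.26 log units; within the scatter). The estimate for compound 3 in this assay is 25 ug/mL, with a range from 10 ug/mL to 60 ug/mL.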

Compound 3, half-maximal inhibitory concentration: 52 ug/mL
For compound 3 the middle estimate is 2.1-fold (0.32 log units) below the measured one; the measured number falls inside the stated range.
By their numbers in this assay, from the lowest: compound 1; then compounds 2 and 3 (each within the scatter of the next).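

In this assay, anilino in place of hydrogen on an aromatic carbon, para to a large group, gives a 1.1-fold higher number from compound 2 to compound 3 (0.05 log units; within the scatter), so compound 2 and compound 3 cannot be told apart on this read-out. This position of the phenyl ring therefore accepts the anilino group, with its added aromatic ring and hydrogen-bond donor, without a measurable difference, and a larger group on the ring attached to the core does not by itself give a lower number, unlike what a 2.9-fold higher number from compound 1 to compound 2 (0.46 log units; beyond the scatter) alone might suggest. No measurement on hand offers an explanation for this result.

The compounds shown leave open whether a small amine, such as an amino group, or a carboxylic acid at the same place would separate from compound 2 in this assay. They also leave open what sets compound 1 apart from compound 2: a phenoxymethyl group on the same carbon would help separate the contribution of the oxymethyl link from that of the naphthalene ring.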